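From a Benzyl Ester to a Dichlorophenyl Group

The source may report more compounds than this note shows. Statements on the series, on what has been measured and on what is new or still open speak of the compounds shown alone.

In a functional assay on SEM cells (Homo sapiens) for cytotoxicity, with a stated time of 72 h (a lower number here means that less compound is needed, a higher number that more compound is needed for the effect), compound 1 (`C=C[C@@](C)(/C=C/c1ccc(OS(=O)(=O)c2ccc(C)cc2)cc1)CCC=C(C)C`) gives > 43400 nM, which is a limit of the assay and not a number. Compound 2 (`C=C[C@@](C)(/C=C/c1ccc(O)c(/C=C/C(=O)OCc2ccccc2)c1)CCC=C(C)C`) gives > 36600 nM in this assay, and this too is only a limit. For the measured compounds named here, compound 2 therefore has no exact value, and neither does the only other compound measured so far.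

Compound 3 (`C=C[C@@](C)(/C=C/c1ccc(O)c(/C=C/c2ccc(Cl)c(Cl)c2)c1)CCC=C(C)C`) carries 3,4-dichlorophenyl in place of benzyloxycarbonyl on a double-bonded chain carbon bound to a double-bonded chain carbon. Going by the values given here, no measured step is available to size this change. A modest expected move toward a lower number in this assay is therefore only a cautious estimate, given as an at least 1.6-fold lower number from compound 2 to compound 3 (0.22 log units; that floor lies within the scatter), and compound 3 may also end up reported only as a limit. Compound 3 is estimated at 22000 nM, with an expected range of 7000 nM to 50000 nM.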

Compound 3, half-maximal effective concentration: > 7500 nM
Compound 3 gave a limit, no number; the forecaster's own chance of this, stated with the estimate: 55%; the middle value lies beyond the limit too.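

In this assay compound 3 gives > 7500 nM, which is a limit and not a number. Compound 2 gives > 36600 nM, also a limit. The change from compound 2 to compound 3 therefore cannot be read. The compounds shown leave open what exact concentration any of them needs for the effect.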